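A few compounds are considered here, and "the series" means these few. Any claim that something is new, unique, unknown or untested is made for them only; others in the source may bear on it.

Working notes on a set of salicylanilide-type amides sharing one core, all read in a functional assay on HL-60 cells (Homo sapiens) for cytotoxicity, read by luminescence and CellTiter-Glo, with a stated time of 3 days; a higher number here means a weaker inhibitor, a lower number a stronger inhibitor. Compound 1 `O=C(Nc1ccc(OC(F)(F)F)cc1)c1cc(F)ccc1O` gives 850 nM in this assay. Compound 2 `N#Cc1ccc(NC(=O)c2ccc(Br)cc2O)cc1Cl` gives 440 nM. Compound 3 `N#Cc1ccc(NC(=O)c2cc(-c3cccnc3)ccc2O)cc1` gives 7960 nM, the highest of the three numbers: compound 1 sits below it by a margin beyond the scatter, and compound 2 sits further below it, also beyond the scatter. For the measured compounds named here, compound 3 is the only one of the three that carries a pyridin-3-yl on the core, while compounds 1 and 2 carry halogens instead; with no single-change pairs among the measured compounds, nothing separates the effect of the pyridin-3-yl from that of the other substituents.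

The next compound, compound 4 `N#Cc1ccc(NC(=O)c2ccccc2O)cc1`, is the bare core on the acid side and differs from compound 3 in one place: hydrogen in place of pyridin-3-yl on an aromatic carbon. The group that leaves sits meta to a large group and para to a hydroxy group. Given that compound 3 stands at 7960 nM and both halogen-bearing compounds without the pyridin-3-yl stand lower, the step from compound 3 to compound 4 is expected to bring a lower number, though of a size that may not clear the scatter, estimated at a 1.8-fold lower number from compound 3 to compound 4 (0.25 log units; within the scatter). For compound 4 in this assay the expected value is 4500 nM, within a range from 1500 nM to 14000 nM.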

Compound 4, half-maximal inhibitory concentration: 4620 nM
Compound 4: middle estimate off by 1.0-fold (0.01 log units), on the low side, and the stated range covers the measured number.
By their numbers in this assay, from the lowest: compounds 2 and 1 (each within the scatter of the next); then compounds 4 and 3 (each within the scatter of the next).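

In this assay, for the compounds shown here, this pair gives the first single-change reading: hydrogen in place of pyridin-3-yl on an aromatic carbon, meta to a large group and para to a hydroxy group, gives a 1.7-fold lower number from compound 3 to compound 4 (0.24 log units; within the scatter). The earlier compounds shown here differed in several places at once and could not isolate the pyridin-3-yl, whereas this pair shows that an entire six-membered aromatic ring can leave this position without a step beyond the scatter, so in this read-out pyridin-3-yl and hydrogen cannot be told apart here. No measurement at hand bears on why the two compounds read alike.

Going by these compounds alone, whether an amine, a carboxylic acid or a longer chain on this same aromatic carbon would give a step beyond the scatter remains open, since hydrogen and pyridin-3-yl are the only two groups compared there with everything else held constant. Also open, from the compounds shown here alone, is whether the same exchange would read alike on a compound carrying a different group on the other aromatic ring of the amide, such as the trifluoromethoxy group of compound 1.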